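The source may hold more compounds than are shown below. What is called first, only, known or untested is meant among the compounds shown, and "the series" means these compounds.

Measured compounds:
- Compound 1, `Cc1ccc(F)cc1NC(=O)Nc1cc(C(C)(C)C)nn1-c1ccccc1`: in an assay on isolated protein for inhibition of STE20-like serine/threonine-protein kinase (Homo sapiens), read by thermal shift assay, tested at 10 uM (a lower number here means that the compound stabilises the target less, a higher number that the compound stabilises the target more against heat), compound 1 gives 6 degrees C
- Compound 2, `CC(C)(C)c1cc(NC(=O)Nc2ccc(Cl)cc2)n(-c2ccc(C(F)(F)F)cc2)n1`: in this assay compound 2 gives 0.7 degrees C

Of these two numbers, compound 2 stands lowest. Its nearest neighbour is compound 1, whose shift lies higher by a margin beyond the usual scatter, so the two compounds are clearly separated on this read-out. Among the measured compounds shown here, the two structures differ in more than one place, so no single-point step between them can be drawn, and their values can only be set side by side.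

Compound 3, `CC(C)(C)c1cc(NC(=O)Nc2ccc(Cl)cc2)n(-c2ccc(OC(F)(F)F)cc2)n1`, has not yet been measured. It differs from compound 2 in one place only: trifluoromethoxy in place of trifluoromethyl on an aromatic carbon. For the measured compounds named here, no measured pair in this set shows a change of this kind, so there is no step to lean on. The expectation is therefore that the step from compound 2 to compound 3 will be no larger than the scatter, and the estimate a number 0.30 degrees C higher from compound 2 to compound 3 (within the scatter) reflects that. On that basis, compound 3 is expected to give about 1 degrees C in this assay, with a likely range from -0.5 degrees C to 3 degrees C.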

Compound 3, shift of the target's melting temperature: 0.2 degrees C
The estimate for compound 3 lay 0.80 degrees C above the measured number; the measured number falls inside the stated range.
By their numbers in this assay, from the lowest: compounds 3 and 2 (each within the scatter of the next); then compound 1.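

In this assay, among the compounds shown here, the change from trifluoromethyl to trifluoromethoxy on an aromatic carbon, para to a large group, gives a number 0.50 degrees C lower from compound 2 to compound 3 (within the scatter) and provides the first step in this set that can be read at a single place. The entering group carries an oxygen and a hydrogen-bond acceptor that the leaving group lacks, yet at this position the step stays within the usual scatter, so compound 2 at 0.7 degrees C and compound 3 at 0.2 degrees C cannot be told apart on this read-out. No measurement of any property of the two groups accompanies the result, so the step stands without an explanation.

The compounds shown do not tell whether an amine, a carboxylic acid or a longer chain at this same place would also read like trifluoromethyl and trifluoromethoxy, or would separate from them beyond the scatter. They also leave open whether this change would remain as small in a compound otherwise built like compound 1 in place of compound 2.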